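The source may report more compounds than this note shows. Statements on the series, on what has been measured and on what is new or still open speak of the compounds shown alone.

Measured in a functional assay on MCF7 cells (Homo sapiens) for cytotoxicity; on this read-out lower numbers stand for stronger inhibition and higher numbers for weaker inhibition:

- compound 1 `C=C/C=C\[C@H](C)[C@H](OC(N)=O)[C@@H](C)[C@H](O)[C@@H](C)C/C(C)=C\[C@H](C)[C@@H](O)[C@@H](C)/C=C\[C@@H](O)C[C@@H]1OC(=O)[C@H](C)[C@@H](O[Si](C)(C)C(C)(C)C)[C@H]1C`: 960 nM
- compound 2 `C=C/C=C\[C@H](C)[C@H](OC(N)=O)[C@@H](C)[C@H](O)[C@@H](C)CC(=C)[C@H]1[C@H](C)[C@@H](O)[C@@H](C)[C@@H]1/C=C/C[C@@H]1OC(=O)[C@H](C)[C@@H](O)[C@H]1C`: 130 nM
- compound 3 `C=C/C=C\[C@H](C)[C@H](OC(N)=O)[C@@H](C)[C@H](O)[C@@H](C)C[C@@](C)(O)[C@H]1[C@H](C)[C@@H](O)[C@@H](C)[C@@H]1/C=C/C[C@@H]1OC(=O)[C@H](C)[C@@H](O)[C@H]1C`: 2360 nM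

Compound 3, at 2360 nM, carries the highest number of the three and so shows the weakest inhibition in this set. Its gaps to compound 1 and to compound 2 both lie beyond the scatter, and the gap to compound 2 is the wider one.

The next compound to be tested is compound 4 `C=C/C=C\[C@H](C)[C@H](OC(N)=O)[C@@H](C)[C@H](O)[C@@H](C)C[C@](C)(O)[C@H]1[C@H](C)[C@@H](O)[C@@H](C)[C@@H]1/C=C/C[C@@H]1OC(=O)[C@H](C)[C@@H](O)[C@H]1C`. The change from compound 3 is confined to configuration: the two compounds have the same atoms and bonds and differ only in configuration as drawn: 1 of 17 stereo elements differ; a stereocentre at a saturated chain carbon is drawn R in compound 3 and S in compound 4. A stereocentre at a saturated chain carbon is drawn R in compound 3 and S in compound 4, while the atoms and bonds stay the same.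

For the measured compounds named here, no two measured compounds differ in only one place, so the data give no direct size for a change of this kind, and they do not settle its direction. A small change, within the scatter, is therefore the working expectation, though a larger move either way remains possible. The wide range reflects how far apart compound 2 at 130 nM and compound 3 at 2360 nM lie.

The estimated 1.2-fold lower number from compound 3 to compound 4 (0.07 log units; within the scatter) is small. For compound 4 the expected value is 2000 nM, within an estimated range of 500 nM to 7000 nM.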

Compound 4, half-maximal inhibitory concentration: 1730 nM
Compound 4: middle estimate off by 1.2-fold (0.06 log units), on the high side; the range from low to high includes it.
By their numbers in this assay, from the lowest: compound 2; then compounds 1, 4 and 3 (each within the scatter of the next, the first and the last beyond it).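

In this assay, for the compounds shown here, the first step that can be read at a single place, a stereocentre at a saturated chain carbon drawn R and then S, comes to a 1.4-fold lower number from compound 3 to compound 4 (0.13 log units; within the scatter). The earlier compounds shown here gave no direct size for a change of this kind, and this step now supplies one: on this read-out, the two drawn configurations at this carbon cannot be told apart from the ordinary spread of repeated measurements. The comparison concerns this one stereocentre alone, and nothing else in the structures can stand behind the step: the fact that compounds 3 and 4 differ only in the configuration as drawn

The compounds shown leave open whether a change of configuration at any other stereocentre in the shared core would be equally small, and whether this one would stay so with an amine or a longer chain in place of the hydroxyl group on this carbon. They also leave open whether a step of this size would hold on cells other than those of this assay.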